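The compounds below may be only part of what the source reports. "The series", "measured", "known", "first", "only" and "open" are said of these compounds alone.

Compound 2 `C[Se]/C(=N\C(=O)c1ccno1)NC(=O)c1ccno1` and compound 1 `CS/C(=N\C(=O)c1ccno1)NC(=O)c1ccno1` share one core and differ in a single place. In a functional assay on HepG2 cells (Homo sapiens) for cytotoxicity, read by MTT assay, with a stated time of 72 h (a lower number here means a stronger inhibitor of growth, a higher number a weaker inhibitor of growth), compound 2 gives 9350 nM. For compound 1 only a limit of this assay is known, > 100000 nM, so no number stands behind it (the limit of > 100000 nM in this assay, at which 1 of the 3 values shown sits). The change from compound 2 to compound 1 is a group of 2 heavy atoms (1 carbon, 1 sulfur; no ring) in place of a group of 2 heavy atoms (1 carbon, 1 selenium; no ring), on a carbon with a double bond to nitrogen, and the step it made is an at least 10-fold higher number from compound 2 to compound 1 (1.02 log units; beyond the scatter). Compound 3 `C[Se]/C(=N\C(=O)c1cnc2ccccc2c1)NC(=O)c1cnc2ccccc2c1` carries a different core; how that core differs from the core of compound 2 is not broken down here. In this assay compound 3 gives 23700 nM. Compound 4 `CS/C(=N\C(=O)c1cnc2ccccc2c1)NC(=O)c1cnc2ccccc2c1` stands to compound 3 as compound 1 stands to compound 2, through the same change (a group of 2 heavy atoms (1 carbon, 1 sulfur; no ring) in place of a group of 2 heavy atoms (1 carbon, 1 selenium; no ring), on a carbon with a double bond to nitrogen). For compound 4 the expected step in this assay is an 11-fold higher number from compound 3 to compound 4 (1.02 log units; beyond the scatter). That expectation rests on the measured at least 10-fold higher number from compound 2 to compound 1 (1.02 log units; beyond the scatter). Compound 4 is therefore estimated at 250000 nM, quite possibly reported only as a limit.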

Compound 4, concentration for total growth inhibition: > 100000 nM
Compound 4 ended at the assay's limit (the forecaster's own chance of this, stated with the estimate: 75%); the middle value does not contradict the limit.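

In this assay, methylsulfanyl in place of the selenium-bearing group on the core of compound 3 gives an at least 4.2-fold higher number from compound 3 to compound 4 (0.62 log units; beyond the scatter) and so moves the number the same way as on the core of compound 2. The direction of the change therefore carries over between these two cores: the same change on two cores in this assay, an at least 10-fold higher number (1.02 log units; beyond the scatter) from compound 2 to compound 1 and an at least 4.2-fold higher number (0.62 log units; beyond the scatter) from compound 3 to compound 4; the limit leaves it open whether they differ. What this does not show is the true size of the step on either core, nor whether the two sizes match: the limit of > 100000 nM in this assay, at which 2 of the 4 values shown sit.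

The compounds shown leave open how a longer chain such as ethyl on the sulfur or selenium, or an amine in that place, would read in this assay. They also leave open whether the change holds on any core beyond these two.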